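This account rests on a few compounds, and the source may have more. Where it says the series, first, only, none or still open, it means among the compounds named here.

Of the compounds shown here, two have so far been tested in an ADME assay on MDCK cells (Canis lupus familiaris) for cytotoxicity, read by microscopy, with a stated time of 48 h; a lower number here means that less compound is tolerated, a higher number that more compound is tolerated. Compound 1 `CCCCc1csc(CN[C@@H]2C[C@H]3C[C@@H]([C@H]2C)C3(C)C)c1` gives 12500 nM, and compound 2 `C[C@H]1[C@H](NCc2ccc(C(C)(C)C)s2)C[C@H]2C[C@@H]1C2(C)C` gives 780 nM. Of these two numbers compound 2 stands lowest, so the cells tolerate less of it than of compound 1, and the gap between them lies well beyond the scatter of repeated measurements.

Compound 3 `CSc1ccc(CN[C@@H]2C[C@H]3C[C@@H]([C@H]2C)C3(C)C)s1` has not yet been measured in this assay. It differs from compound 2 in one place: methylsulfanyl in place of tert-butyl on an aromatic carbon. Among the compounds with values here, the two measured compounds differ from each other in more than this one place, so no measured step shows directly how such a swap shifts the number, and any expectation rests on the single value of compound 2.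

For the move in this assay a modest rise is expected, a 2.6-fold higher number from compound 2 to compound 3 (0.41 log units; beyond the scatter), that is, somewhat more compound tolerated. Compound 3 is estimated at 2000 nM, with a range from 500 nM to 8000 nM.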

Compound 3, minimum cytotoxic concentration: 25000 nM
The estimate for compound 3 lay 13-fold (1.10 log units) below the measured number; measured number outside the range, above it.
By their numbers in this assay, from the lowest: compound 2; then compounds 1 and 3 (each within the scatter of the next).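

In this assay, methylsulfanyl in place of tert-butyl on this aromatic carbon, next to the ring sulfur, brings a 32-fold higher number from compound 2 to compound 3 (1.51 log units; beyond the scatter), so a change at this single position can shift the number by a large amount. The two groups differ in more than one way: the group that leaves has 4 heavy atoms, all carbon, while the group that enters has 2, one of them sulfur, and adds 1 hydrogen-bond acceptor. Nothing available explains the rise or links it to either of these differences.

Going by these compounds, it remains open whether the rise follows the smaller group or the sulfur atom, which a methoxy or an ethyl group on the same carbon could help to separate. On these data alone, it also remains open whether the same swap would shift the number as far on another core.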